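Adding a second chloro to a weak antiproliferative pyrazoline

A few compounds are considered here, and "the series" means these few. Any claim that something is new, unique, unknown or untested is made for them only; others in the source may bear on it.

Measured compounds:
- compound 1, `c1ccc(C2=NN(c3ccc(-c4ccccc4)nn3)C(c3ccccc3)C2)cc1`: 40900 nM
- compound 2, `Clc1ccc(C2CC(c3ccccc3)=NN2c2ccc(-c3ccccc3)nn2)cc1`: 100000 nM
- compound 3, `Clc1ccc(C2=NN(c3ccc(-c4ccccc4)nn3)C(c3ccccc3)C2)cc1`: 100000 nM

In a functional assay on Caco-2 cells (Homo sapiens) for antiproliferative activity, read by MTT assay, with a stated time of 24 h (on this read-out higher numbers stand for weaker inhibition and lower numbers for stronger inhibition), compound 3 gives 100000 nM, which puts it level with compound 2 and, together with compound 2, at the highest number of the three, well above compound 1, which gives 40900 nM. Compound 4, `Clc1ccc(C2=NN(c3ccc(-c4ccccc4)nn3)C(c3ccc(Cl)cc3)C2)cc1`, differs from compound 3 in one place: chloro in place of hydrogen on an aromatic carbon. Two earlier steps show the same kind of change. The step of a 2.4-fold higher number from compound 1 to compound 2 (0.39 log units; beyond the scatter) and the step of a 2.4-fold higher number from compound 1 to compound 3 (0.39 log units; beyond the scatter) each put a chloro onto a phenyl ring and each raised the number modestly, beyond the scatter. On that basis a second chloro on compound 4 is expected to leave the number where it is or raise it further, so a small step of a 1.3-fold higher number from compound 3 to compound 4 (0.11 log units; within the scatter) toward weaker inhibition is expected. Compound 4 is therefore estimated at 130000 nM in this assay, with a likely range from 60000 nM to 300000 nM, and a real chance that only a limit rather than a number is recorded.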

Compound 4, half-maximal inhibitory concentration: > 100000 nM
Compound 4: only a limit was reported; the forecaster's own chance of this, stated with the estimate: 50%; the middle value does not contradict the limit.
By their numbers in this assay, from the lowest: compound 1; then compounds 2 and 3 (each within the scatter of the next).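

In this assay compound 4 gives > 100000 nM, which is a limit of the assay and not a number. The steps to compound 4 therefore cannot be read in size; a chloro on the remaining phenyl, turning phenyl into 4-chlorophenyl, shows only a number no lower from compound 3 to compound 4 (the limit leaves the size open) and a number no lower from compound 2 to compound 4 (the limit leaves the size open). Whether this chloro counts for as much as the first one stays unsettled: the same change on two cores in this assay, a 2.4-fold higher number (0.39 log units; beyond the scatter) from compound 1 to compound 2 and a number no lower (the limit leaves the size open) from compound 3 to compound 4; the limit leaves it open whether they differ

From the compounds shown here alone, whether a methoxy, an amine or a carboxylic acid on an aromatic carbon, para to a large group, would give a number lower than that of compound 1, at 40900 nM, stays open. Also open, going by these compounds, is whether any group at this position could bring stronger inhibition on the shared core.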